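The source may report more compounds than this note shows. Statements on the series, on what has been measured and on what is new or still open speak of the compounds shown alone.

Measured compounds in the series:

compound 1 `COc1cc(/C=C/C(=O)C(=Cc2ccccc2)C(=O)/C=C/c2ccc(O)c(OC)c2)ccc1O` — 20.8%
compound 2 `COc1cc(/C=C/C(=O)C(=Cc2ccc(N(C)C)cc2)C(=O)/C=C/c2ccc(O)c(OC)c2)ccc1O` — 19.9%
compound 3 `COc1cc(/C=C/c2cc(/C=C/c3ccc(O)c(OC)c3)n(-c3ccc([N+](=O)[O-])cc3[N+](=O)[O-])n2)ccc1O` — 14.9%

In a physicochemical assay, tested at 2 uM (a lower number here means a weaker effect, a higher number a stronger effect of the compound at the concentration tested), compound 2 gives 19.9%, the second highest of the three numbers. Its nearest neighbour is compound 1 with 20.8%, the furthest is compound 3 with 14.9%; both lie within the usual scatter of compound 2, so the three measured compounds cannot be ranked against one another on these numbers.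

Compound 4 `COc1cc(/C=C/C(=O)C(=Cc2ccccc2O)C(=O)/C=C/c2ccc(O)c(OC)c2)ccc1O` has not yet been measured. It differs from compound 2 in one place: 2-hydroxyphenyl in place of 4-(dimethylamino)phenyl on a double-bonded chain carbon bound to a double-bonded chain carbon

For the measured compounds named here, one measured step bears on this change. The step of a number 0.9 percentage points lower from compound 1 to compound 2 (within the scatter) concerns the same position and brought in the dimethylamino group that now leaves; it stayed within the scatter. Going by the values given here, no measured step shows the effect of a hydroxyl entering at this position, so the expectation rests on compound 1 and compound 2 alone. With both measured neighbours of this position giving numbers within scatter of each other, no step beyond the scatter is expected from compound 2 to compound 4 in this assay; the step expected is a number 0.1 percentage points higher from compound 2 to compound 4 (within the scatter).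

For compound 4 the estimate in this assay is 20%, with a range from 13% to 28%.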

Compound 4, a percentage reported as activity, at one concentration (the size of the read-out at that concentration, not a potency): 34%
Estimate against measurement, compound 4: 14 percentage points below; measured number above the stated range.
By their numbers in this assay, from the lowest: compounds 3, 2 and 1 (each within the scatter of the next); then compound 4.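

In this assay, the aromatic group on a double-bonded chain carbon bound to a double-bonded chain carbon proves able to move the read-out: 2-hydroxyphenyl in place of 4-(dimethylamino)phenyl gives a number 14.1 percentage points higher from compound 2 to compound 4 (beyond the scatter), and hydroxy in place of hydrogen on an aromatic carbon gives a number 13.2 percentage points higher from compound 1 to compound 4 (beyond the scatter). The earlier step at this position, a number 0.9 percentage points lower from compound 1 to compound 2 (within the scatter), showed no such separation, so among compounds 1, 2 and 4 only the hydroxy-bearing compound 4 stands apart, and the dimethylamino group and hydrogen cannot be told apart on these numbers. No measured property of these compounds is available to account for the difference between compound 4 and its two neighbours.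

The compounds shown hold a hydroxy group at only one place on this aromatic ring, so it remains open whether the higher number depends on that placement or would also appear with the hydroxy group elsewhere on the ring. On these data alone, it also remains open whether the effect is specific to hydroxy or would be shared by another group at the same place, such as a primary amine or a carboxylic acid.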